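This account rests on a few compounds, and the source may have more. Where it says the series, first, only, none or still open, it means among the compounds named here.

Measured so far in a functional assay on Jurkat cells (Homo sapiens) for activation, with a stated time of 24 h; a lower number here means that less compound is needed, a higher number that more compound is needed for the effect: compound 1 `Oc1ccccc1CNc1ccc(-c2ccccc2)cc1` gives 1820 nM; compound 2 `CC(C)(C)c1ccc(-c2ccc(NCc3ccccc3O)cc2)cc1` gives "not active" (no number reported); compound 3 `Oc1ccccc1CNc1ccc(-c2ccccc2)c(F)c1` gives 2850 nM.

The step of a 1.6-fold higher number from compound 1 to compound 3 (0.19 log units; within the scatter), fluoro in place of hydrogen on an aromatic carbon, lies within the scatter, so those two numbers cannot be ranked against each other, and compound 2 gave no number at all. Compound 4 `Cc1cc(NCc2ccccc2O)ccc1-c1ccccc1` differs from compound 3 by methyl in place of fluoro on an aromatic carbon. For the measured compounds named here, the one measured step at that position, a 1.6-fold higher number from compound 1 to compound 3 (0.19 log units; within the scatter), stayed within the scatter, and no measured pair shows what a methyl there does, so for compound 4 an expected step of a 1.1-fold lower number from compound 3 to compound 4 (0.06 log units; within the scatter) in this assay should stay within the scatter. Compound 4 is therefore estimated at 2500 nM, with a range from 900 nM to 7000 nM.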

Compound 4, half-maximal effective concentration: 8610 nM
Beside the measured number, compound 4's estimate is 3.4-fold (0.54 log units) below it; measured number outside the range, above it.
By their numbers in this assay, from the lowest: compounds 1 and 3 (each within the scatter of the next); then compound 4.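

In this assay, methyl in place of fluoro gives a 3.0-fold higher number from compound 3 to compound 4 (0.48 log units; beyond the scatter), and methyl in place of hydrogen gives a 4.7-fold higher number from compound 1 to compound 4 (0.67 log units; beyond the scatter). For the compounds shown here, the earlier swap of hydrogen for fluoro stayed within the scatter, so this is the first change on this aromatic carbon that can be read as a real shift. Here, more compound is needed with methyl on that carbon than with either of the other two groups. As far as these compounds go, whether an ethyl group or an amine on the same carbon would raise the number further or bring it back towards that of compound 1 stays open. Nothing available here gives a reason for the step.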